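A few compounds are considered here, and "the series" means these few. Any claim that something is new, unique, unknown or untested is made for them only; others in the source may bear on it.

Compound 3 `Cc1nc(C)n(CC(=O)N2CCN(c3sc(C(F)(F)F)nc3-c3cnc(C(C)(C)C)nc3)C[C@H]2C)n1` stands at the highest number of the three measured compounds in a functional assay on U2OS cells for antagonist activity at C-X-C chemokine receptor type 3 (Homo sapiens), read by beta-arrestin recruitment (on this read-out higher numbers stand for weaker inhibition and lower numbers for stronger inhibition), giving 1030 nM. In this assay compound 1 `Cc1nc(C)n(CC(=O)N2CCN(c3sc(C(F)(F)F)nc3-c3cnc(OC(C)C)nc3)C[C@H]2C)n1` gives 138 nM, and compound 2 `Cc1ncc(-c2nc(C(F)(F)F)sc2N2CCN(C(=O)Cn3nc(C)nc3C)[C@H](C)C2)cn1` gives 578 nM. The step of a 7.5-fold higher number from compound 1 to compound 3 (0.87 log units; beyond the scatter) lies beyond the scatter, whereas the step of a 1.8-fold higher number from compound 2 to compound 3 (0.25 log units; within the scatter) does not. Compound 4 `Cc1nc(C)n(CC(=O)N2CCN(c3sc(C(F)(F)F)nc3-c3cnc(N4CCCC4)nc3)C[C@H]2C)n1` differs from compound 3 by pyrrolidin-1-yl in place of tert-butyl on an aromatic carbon, on an aromatic carbon between two ring nitrogen atoms. Among the measured compounds shown here, the one measured exchange of tert-butyl for a group carrying a hetero atom at this place is a 7.5-fold higher number from compound 1 to compound 3 (0.87 log units; beyond the scatter), and read in reverse it points to a lower number. Compound 4 is therefore expected to show the step of a 3.4-fold lower number from compound 3 to compound 4 (0.54 log units; beyond the scatter). In this assay compound 4 is estimated at 300 nM, with a range from 90 nM to 1000 nM.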

Compound 4, half-maximal inhibitory concentration: 523 nM
Estimate against measurement, compound 4: 1.7-fold (0.24 log units) below, within the range that was stated.
By their numbers in this assay, from the lowest: compound 1; then compounds 4, 2 and 3 (each within the scatter of the next).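

At this place, on an aromatic carbon between two ring nitrogen atoms, a hetero atom on the incoming group is not enough to match isopropoxy in this assay: a 3.8-fold higher number from compound 1 to compound 4 (0.58 log units; beyond the scatter) stays beyond the scatter. Pyrrolidin-1-yl is not separated from tert-butyl or methyl, with a 2.0-fold lower number from compound 3 to compound 4 (0.29 log units; within the scatter) and a 1.1-fold lower number from compound 2 to compound 4 (0.04 log units; within the scatter) both within the scatter, so among these four compounds only isopropoxy stands apart. Nothing given explains this difference. As far as these compounds go, it remains open whether methoxy, a longer ether chain or an open-chain amine such as dimethylamino would fall with isopropoxy or with pyrrolidin-1-yl.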